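The source may hold more compounds than are shown below. What is called first, only, known or untested is meant among the compounds shown, and "the series" means these compounds.

Among the measured compounds shown here, compound 2 (`Cc1cn(CCC2(N)OC(=O)C(OCc3ccccc3)=C2OCc2ccccc2)c(=O)[nH]c1=O`) is one of only two compounds so far tested in a functional assay on HepG2 cells (Homo sapiens) for inhibition, read by MTT assay, with a stated time of 72 h; on this read-out higher numbers stand for weaker inhibition and lower numbers for stronger inhibition. In this assay compound 2 gives no number but a limit of the assay, > 100000 nM. Its closest measured relative, compound 1 (`NC1(CCn2ncc(=O)[nH]c2=O)OC(=O)C(OCc2ccccc2)=C1OCc1ccccc1`), likewise reaches only a limit in this assay, namely > 100000 nM. For the measured compounds named here, the single step between measured compounds, a step that the two limits leave unreadable from compound 1 to compound 2, therefore has no readable size, since (the limit of > 100000 nM in this assay, at which 2 of the 2 values shown sit). Compound 3 (`NC1(CCn2c(=O)[nH]c(=O)[nH]c2=O)OC(=O)C(OCc2ccccc2)=C1OCc1ccccc1`) differs from compound 2 in one place: a group of 9 heavy atoms (3 carbon, 3 nitrogen, 3 oxygen; one six-membered aromatic ring with 3 hetero atoms) in place of a group of 9 heavy atoms (5 carbon, 2 nitrogen, 2 oxygen; one six-membered aromatic ring with 2 hetero atoms), on a saturated chain carbon, two bonds along the chain from a saturated ring carbon. Going by the values given here, no measured step bears on this exchange, and the only step available is itself unreadable. The expectation for compound 3 is accordingly that it will again sit at the limit, with an expected step that the limit leaves unreadable from compound 2 to compound 3 that cannot be separated from no change at all. Compound 3 is estimated at 150000 nM, with a range from 60000 nM to 500000 nM, and most likely reported only as a limit.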

Compound 3, half-maximal inhibitory concentration: > 100000 nM
Compound 3 was reported as a limit; the forecaster's own chance of this, stated with the estimate: 85%; the middle value is on the limit's open side.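

Among the compounds shown here, no step between compound 1, compound 2 and compound 3 can be read in this assay, since each gives only a limit of the assay and not a number: the limit of > 100000 nM in this assay, at which 3 of the 3 values shown sit.
Going by these compounds, whether these three compounds truly differ in strength, and what change to the shared core would give a readable number, remains open.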